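Series notes: trifluoromethyl in place of methoxycarbonyl

The source may hold more compounds than are shown below. What is called first, only, known or untested is meant among the compounds shown, and "the series" means these compounds.

Measured in an ADME assay on HEK293 cells (Homo sapiens) for cytotoxicity, with a stated time of 72 h; a lower number here means that less compound is needed, a higher number that more compound is needed for the effect:
- Compound 1 `CC(=O)c1ccc(NC(=O)Nc2cc(C)nc3ccccc23)cc1`: > 25000 nM, a limit of the assay
- Compound 2 `COC(=O)c1ccc(NC(=O)Nc2cc(C)nc3ccccc23)cc1`: 15000 nM

For the measured compounds named here, compound 2 holds the only actual number so far in this assay. Compound 3 `Cc1cc(NC(=O)Nc2ccc(C(F)(F)F)cc2)c2ccccc2n1` differs from it as follows: trifluoromethyl in place of methoxycarbonyl on an aromatic carbon. Going by the values given here, the one measured step bears on this change only loosely: an at least 1.6-fold lower number from compound 1 to compound 2 (0.22 log units; that floor lies within the scatter). That step is a floor and not a measured size, so no step beyond the scatter is expected in this assay. The estimated change is a 1.3-fold lower number from compound 2 to compound 3 (0.10 log units; within the scatter). For compound 3 the expected value is 12000 nM, with an estimated range of 4000 nM to 25000 nM.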

Compound 3, half-maximal effective concentration: 25000 nM
Compound 3: middle estimate off by 2.1-fold (0.32 log units), on the low side; the measured number falls inside the stated range.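

In this assay, trifluoromethyl in place of methoxycarbonyl on an aromatic carbon, para to a large group, gives a 1.7-fold higher number from compound 2 to compound 3 (0.22 log units; within the scatter). For the compounds shown here, this is the first step here with a measured size, and it shows that exchanging a group with hydrogen-bond acceptors for one without leaves the number within the scatter for this pair. Trifluoromethyl in place of acetyl on an aromatic carbon gives a number no higher from compound 1 to compound 3 (the limit leaves the size open). That step cannot be read because the value of compound 1 is a limit: the limit of > 25000 nM in this assay, at which 1 of the 3 values shown sits.

On these data alone, whether an amine, a carboxylic acid or a nitrile at this position would give a step beyond the scatter remains open. So does the effect of any change on the shared core.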